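Removing one methoxy group from a pyrazolyl chalcone

The source may hold more compounds than are shown below. What is called first, only, known or untested is meant among the compounds shown, and "the series" means these compounds.

Of the compounds shown here, two of a shared core have been tested so far. Compound 1 `COc1ccc(-c2cc(/C=C/C(=O)c3ccc(N)cc3)[nH]n2)cc1` carries a single methoxy group on its outer benzene ring, while compound 2 `COc1cc(-c2cc(/C=C/C(=O)c3ccc(N)cc3)[nH]n2)cc(OC)c1OC` carries three. In a functional assay on MDA-MB-468 cells (Homo sapiens) for inhibition, read by sulforhodamine B assay, with a stated time of 48 h (a higher number here means that more compound is tolerated, a lower number that less compound is tolerated), compound 1 gives 7450 nM. In this assay compound 2 gives 8420 nM. For the measured compounds named here, of the two numbers known, that of compound 2 sits alongside that of compound 1, the two differing only within the usual scatter of repeated measurements, so nothing separates them.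

Compound 3 `COc1ccc(-c2cc(/C=C/C(=O)c3ccc(N)cc3)[nH]n2)cc1OC` is the next member of the set and is not yet measured in this assay. It differs from compound 2 in one place: hydrogen in place of methoxy on an aromatic carbon. Since going from one methoxy group in compound 1 to three in compound 2 left the number essentially unchanged, no step beyond the scatter is expected for this assay in either direction when one of the three is removed again. The expected step from compound 2 to compound 3 is therefore a 1.1-fold lower number from compound 2 to compound 3 (0.03 log units; within the scatter). Compound 3 is estimated to give about 7800 nM, with a plausible range from 3500 nM to 17000 nM.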

Compound 3, concentration lethal to 50% of the cells: 7800 nM
Beside the measured number, compound 3's estimate shows no gap at the digits printed, within the range that was stated.
By their numbers in this assay, from the lowest: compounds 1, 3 and 2 (each within the scatter of the next).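

The earlier pair differed by two methoxy groups at once, so it could not show what a single one contributes, whereas these steps each change just one. In this assay the loss of the methoxy group that sits ortho to a methoxy group and meta to a large group gives a 1.1-fold lower number from compound 2 to compound 3 (0.03 log units; within the scatter) and the addition of one methoxy group to an aromatic carbon gives a 1.0-fold higher number from compound 1 to compound 3 (0.02 log units; within the scatter) on the same read-out. Across these single changes, methoxy and hydrogen on the outer benzene ring cannot be told apart in this measurement, and no separate measurement is available to explain that finding.

Only hydrogen and methoxy appear at this place in the compounds shown, so it remains open whether a fluorine atom, an amine, a carboxylic acid or a longer chain such as butoxy would also leave the number within the scatter. The rest of the shared core is the same in all three compounds, so these results say nothing about how changes elsewhere would read.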